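Acyl chain length on the ring nitrogen: removing the acyl group

A few compounds are considered here, and "the series" means these few. Any claim that something is new, unique, unknown or untested is made for them only; others in the source may bear on it.

Measured so far:
compound 1 `CC(=O)N1c2ccccc2CCC1C(=O)Nc1cc(C(F)(F)F)cc(C(F)(F)F)c1` — > 70000 nM
compound 2 `CCCCCCCCC(=O)N1c2ccccc2CCC1C(=O)Nc1cc(C(F)(F)F)cc(C(F)(F)F)c1` — 4520 nM
compound 3 `CCC(=O)N1c2ccccc2CCC1C(=O)Nc1cc(C(F)(F)F)cc(C(F)(F)F)c1` — 7720 nM

All three share one core and differ only in the acyl group on the ring nitrogen. In a functional assay on ACHN cells (Homo sapiens) for cytotoxicity, read by sulforhodamine B assay, with a stated time of 72 h (a higher number here means a weaker inhibitor of growth, a lower number a stronger inhibitor of growth), compound 1 gives only a limit, > 70000 nM, and no number. Compound 2 gives 4520 nM in this assay. Compound 3 gives 7720 nM in this assay, the highest of the two numbers shown; its nearest neighbour is compound 2, and a 1.7-fold higher number from compound 2 to compound 3 (0.23 log units; within the scatter).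

Within the data shown here, the steps that bear on the next change are an at least 9.0-fold lower number from compound 1 to compound 3 (0.95 log units; beyond the scatter) and an at least 15-fold lower number from compound 1 to compound 2 (1.18 log units; beyond the scatter): lengthening the acyl chain from acetyl lowers the number, and the acetyl compound itself sits at the assay limit (the limit of > 70000 nM in this assay, at which 1 of the 3 values shown sits).

Compound 4 `O=C(Nc1cc(C(F)(F)F)cc(C(F)(F)F)c1)C1CCc2ccccc2N1` has not been measured. It differs from compound 3 by hydrogen in place of propanoyl on a nitrogen on an aromatic ring in a ring. This goes the opposite way from the lengthening that helped, so a considerably higher number is expected, and a limit is a real possibility. For compound 4 the estimate in this assay is 50000 nM, with a range from 12000 nM to 200000 nM. The expected step is a 6.5-fold higher number from compound 3 to compound 4 (0.81 log units; beyond the scatter).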

Compound 4, concentration for 50% growth inhibition: 8190 nM
For compound 4 the middle estimate is 6.1-fold (0.79 log units) above the measured one, outside the stated range (below it).
By their numbers in this assay, from the lowest: compounds 2, 3 and 4 (each within the scatter of the next). At a limit, above all of these: compound 1.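

In this assay the removal of the acyl group gives a 1.1-fold higher number from compound 3 to compound 4 (0.03 log units; within the scatter) and a 1.8-fold higher number from compound 2 to compound 4 (0.26 log units; within the scatter) so hydrogen on this nitrogen matches propanoyl and octylcarbonyl, and an acyl group here is not required for this level of growth inhibition. Hydrogen in place of acetyl gives an at least 8.5-fold lower number from compound 1 to compound 4 (0.93 log units; beyond the scatter) and so acetyl alone stands apart, while the gain seen on lengthening the chain from acetyl does not read as a simple trend with chain length, since hydrogen, with no chain, falls with the two longer acyl groups. Compound 1 is the only one that gives a limit and not a number: the limit of > 70000 nM in this assay, at which 1 of the 4 values shown sits.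

Open, as far as these compounds go, is whether a non-acyl group on this nitrogen, such as a simple alkyl chain or a benzyl group, stays level with these compounds, and whether butanoyl or a chain longer than octylcarbonyl does. What sets acetyl apart from hydrogen and propanoyl cannot be told from these values.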